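Removing a Second Acetyl from a Weakly Cytotoxic Glycoside

A few compounds are considered here, and "the series" means these few. Any claim that something is new, unique, unknown or untested is made for them only; others in the source may bear on it.

Compound 1 `CC(=O)O[C@@H](C[C@@H]1C(C)=CCC(=O)C1(C)C)/C(C)=C/[C@@H](C/C=C(\C)CC[C@H]1C(C)(C)[C@@H](O[C@@H]2O[C@H](CO)[C@H](O)[C@H](O)[C@H]2O)CC[C@]1(C)OC(C)=O)OC(C)=O` was tested in a functional assay on K562 cells (Homo sapiens) for cytotoxicity, read by spectrophotometry (on this read-out lower numbers stand for stronger inhibition and higher numbers for weaker inhibition), where compound 1 gives 17000 nM. Compound 2 `CC(=O)O[C@@H](C[C@@H]1C(C)=CCC(=O)C1(C)C)/C(C)=C/[C@H](O)C/C=C(\C)CC[C@H]1C(C)(C)[C@@H](O[C@@H]2O[C@H](CO)[C@H](O)[C@H](O)[C@H]2O)CC[C@]1(C)OC(C)=O` differs from compound 1 by hydrogen in place of acetyl on an oxygen on a saturated carbon. In this assay compound 2 reached only a limit of the assay, > 100000 nM. That step, an at least 5.8-fold higher number from compound 1 to compound 2 (0.76 log units; beyond the scatter), ends at the limit of > 100000 nM in this assay, at which 1 of the 2 values shown sits. Compound 3 `CC(=O)O[C@@]1(C)CC[C@H](O[C@@H]2O[C@H](CO)[C@H](O)[C@H](O)[C@H]2O)C(C)(C)[C@@H]1CC/C(C)=C/C[C@@H](O)/C=C(\C)[C@@H](O)C[C@@H]1C(C)=CCC(=O)C1(C)C` carries the same kind of change once more: hydrogen in place of acetyl on an oxygen on a saturated carbon. Within the data shown here, the only measured step that bears on this change, an at least 5.8-fold higher number from compound 1 to compound 2 (0.76 log units; beyond the scatter), points toward weaker inhibition, and compound 2 already stands at the limit, so no move toward a lower number is expected for compound 3 in this assay. Compound 3 is therefore expected to give 200000 nM, between 100000 nM and 1000000 nM. This means an expected step that the limit leaves unreadable from compound 2 to compound 3, and most likely another limit rather than a number.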

Compound 3, half-maximal inhibitory concentration: > 100000 nM
Compound 3: a limit, no number; the forecaster's own chance of this, stated with the estimate: 85%; the middle value lies beyond the limit too.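

In this assay compound 3 gives > 100000 nM, which is a limit and not a number. Compound 2 also stands at a limit, so no step from compound 2 to compound 3 can be read: the limit of > 100000 nM in this assay, at which 2 of the 3 values shown sit.

The compounds shown leave open whether compound 2 and compound 3 differ at all, and what their true values are.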